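One methyl more on compound 2

A few compounds are considered here, and "the series" means these few. Any claim that something is new, unique, unknown or untested is made for them only; others in the source may bear on it.

Measured in an ADME assay on MT4 cells (Homo sapiens) for activation, read by MTT assay; on this read-out lower numbers stand for higher toxicity in this test and higher numbers for lower toxicity in this test:
compound 1 `O=c1cc(Cc2c(F)cccc2Cl)nc(SC2CCCC2)[nH]1`: > 74000 nM
compound 2 `CC(c1cc(=O)[nH]c(SC2CCCC2)n1)c1c(F)cccc1Cl`: > 71000 nM

In this assay compound 2 gives > 71000 nM, and this value is a limit of the assay, not a number. Compound 1 gives > 74000 nM, which is also a limit. Compound 3 `Cc1c(C(C)c2c(F)cccc2Cl)nc(SC2CCCC2)[nH]c1=O` differs from compound 2 in one place: methyl in place of hydrogen on an aromatic carbon. This puts methyl in place of hydrogen on an aromatic carbon, ortho to a large group. For the measured compounds named here, the only measured step that bears on it is a step that the two limits leave unreadable from compound 1 to compound 2. That step also brings in methyl in place of hydrogen, but on a saturated chain carbon bound to two aromatic carbons, and it offers no size to carry over. The expectation therefore rests on the limit of compound 2, > 71000 nM. No change beyond the usual scatter is expected in this assay, in either direction, and the estimated step is an at least 1.0-fold lower number from compound 2 to compound 3 (0.03 log units; that floor lies within the scatter). For compound 3 the estimate is 65000 nM, with an expected range from 25000 nM to 110000 nM.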

Compound 3, half-maximal cytotoxic concentration: > 15000 nM
Compound 3: only a limit was reported; the forecaster's own chance of this, stated with the estimate: 65%; the middle value does not contradict the limit.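

In this assay compound 3 gives > 15000 nM, which is a limit of the assay and not a number. Compound 2 also stands at a limit, and the step from compound 2 to compound 3 cannot be read. The compounds shown leave open where the actual values of these compounds lie and whether the methyl on the aromatic carbon changes the read-out at all.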